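Swapping the bicyclic arm for 2,4-dichlorophenyl on the imidazole

The source may hold more compounds than are shown below. What is called first, only, known or untested is meant among the compounds shown, and "the series" means these compounds.

Compound 2 `O=C1COc2ccc(-c3[nH]c(-c4c[nH]c5ncccc45)nc3-c3ccccc3)cc2N1`: 97.7%
Compound 1 `O=C1COc2ccc(-c3nn(-c4ccc(Br)cc4)cc3-c3ccccc3)cc2N1`: 66.4%

In a functional assay on DLD-1 cells (Homo sapiens) for cytotoxicity, read by colorimetric assay and MTT assay, with a stated time of 3 days, tested at 1 uM (a lower number here means a stronger effect, a higher number a weaker effect of the compound at the concentration tested), compound 2 stands highest of the two numbers, with compound 1 nearest and lower by a margin beyond the scatter. Compound 3 `O=C1COc2ccc(-c3[nH]c(-c4ccc(Cl)cc4Cl)nc3-c3ccccc3)cc2N1` is not yet measured. It differs from compound 2 in one place: a group of 8 heavy atoms (6 carbon, 2 chlorine; one six-membered aromatic ring of carbon only) in place of a group of 9 heavy atoms (7 carbon, 2 nitrogen; one five-membered aromatic ring with 1 hetero atom, one six-membered aromatic ring with 1 hetero atom), on an aromatic carbon. Within the data shown here, no measured pair shows this change, so its effect is open. A modest step to a lower number, expected as a number 19.7 percentage points lower from compound 2 to compound 3 (beyond the scatter), seems reasonable; compound 3 is estimated at 78%, within 50% to 100%.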

Compound 3, a percentage reported as activity, at one concentration (the size of the read-out at that concentration, not a potency): 97.8%
For compound 3 the middle estimate is 19.8 percentage points below the measured one; low and high end bracket the measured number.
By their numbers in this assay, from the lowest: compound 1; then compounds 2 and 3 (each within the scatter of the next).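

In this assay, the exchange on the aromatic carbon between two ring nitrogen atoms gives a number 0.1 percentage points higher from compound 2 to compound 3 (within the scatter), so at this position 2,4-dichlorophenyl, with no hydrogen-bond donors or acceptors, reads the same as the group it replaces, which has both. Both compounds sit at the weak end of the numbers seen here, so this single concentration shows no gain from the change. No available evidence explains this result. On these data alone, whether an amine or a carboxylic acid at this position would give a lower number remains open.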